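The source may report more compounds than this note shows. Statements on the series, on what has been measured and on what is new or still open speak of the compounds shown alone.

Measured compounds:
Compound 1 `C[C@H]1CC(Cl)=C[C@@H](C2CCCCC2)O1` — 19000 nM in a functional assay on A2780 cells (Homo sapiens) for antiproliferative activity; a higher number here means a weaker inhibitor of growth, a lower number a stronger inhibitor of growth
Compound 2 `CC[C@H]1CC(Cl)=C([Si](C)(C)C)[C@@H](C2CCCCC2)O1` — 16000 nM in this assay

Of the compounds shown here, two have been measured in this assay, and both sit at the weak end of the scale. Compound 2 gives 16000 nM, and compound 1 gives 19000 nM; the gap between these two numbers is within the usual scatter of repeated measurements, so nothing separates them. Compound 2 also differs from compound 1 in more than one place, so no single change can be read out of this pair.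

The next compound is compound 3 `C[Si](C)(C)C1=C(Cl)C[C@H](Cc2ccccc2)O[C@@H]1C1CCCCC1`. It differs from compound 2 in one place: phenyl in place of methyl on a saturated chain carbon bound to a saturated ring carbon. Going by the values given here, no measured pair in this set shows what such a change does in this assay, so there is no step to lean on. In the absence of such a step the expectation is for a change that stays close to the scatter, with no clear direction, which means a step from compound 2 to compound 3 of about a 1.3-fold lower number from compound 2 to compound 3 (0.12 log units; within the scatter) is estimated. Compound 3 is therefore expected to give about 12000 nM in this assay, with a range from 3000 nM to 45000 nM.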

Compound 3, concentration for 50% growth inhibition: 34000 nM
Estimate against measurement, compound 3: 2.8-fold (0.45 log units) below; the measured number falls inside the stated range.
By their numbers in this assay, from the lowest: compounds 2, 1 and 3 (each within the scatter of the next, the first and the last beyond it).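

In this assay, phenyl in place of methyl on a saturated chain carbon bound to a saturated ring carbon, which can also be read as ethyl to benzyl, gives a 2.1-fold higher number from compound 2 to compound 3 (0.33 log units; beyond the scatter). Going by these compounds alone, this modest step, beyond the scatter, is the first sign that the group at this place can alter the antiproliferative read-out, since the earlier pair differed in more than one place and could not be read. Here, the change to a larger group with one six-membered aromatic ring goes with weaker growth inhibition, but nothing available explains the shift.

From the compounds shown here alone, this rests on a single pair, so it remains open whether the number rises steadily along a series at this place or whether benzyl is a special case, and a longer chain such as propyl or butyl would help to separate the two. Going by these compounds, it is also open how an amine or a carboxylic acid at this place would read, and whether the same change would have a similar effect on the core of compound 1.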